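The source may hold more compounds than are shown below. What is called first, only, known or untested is meant among the compounds shown, and "the series" means these compounds.

Among the measured compounds shown here, compound 1 `COc1ccc(Nc2nc(-c3cccc(F)c3)nc3ccc(F)cc23)cc1` is the one member of this small set that returns a full number in a functional assay on U-937 cells (Homo sapiens) for cytotoxicity, read by MTT assay, with a stated time of 48 h; on this read-out higher numbers stand for weaker inhibition and lower numbers for stronger inhibition: compound 1 gives 41100 nM. Compound 2 `Oc1cccc(Nc2nc(-c3cccc(F)c3)nc3ccc(F)cc23)c1`, which carries 3-hydroxyphenyl in place of 4-methoxyphenyl on a nitrogen on an aromatic ring, is reported in this assay only as a limit, > 50000 nM. The change between them reads an at least 1.2-fold higher number from compound 1 to compound 2 (0.08 log units; that floor lies within the scatter), and that floor is set by the limit of > 50000 nM in this assay, at which 1 of the 2 values shown sits. Compound 3 `Oc1ccccc1Nc1nc(-c2cccc(F)c2)nc2ccc(F)cc12` differs from compound 1 in a related way: 2-hydroxyphenyl in place of 4-methoxyphenyl on a nitrogen on an aromatic ring. For the measured compounds named here, the only measured step that bears on this move is the one to the hydroxyphenyl isomer, which was too small to separate from the scatter. No step beyond the scatter is therefore expected in this assay, and a limit rather than a number is a real possibility. Compound 3 is expected to give about 50000 nM, ranging from 25000 nM to 100000 nM. This amounts to an expected step of a 1.2-fold higher number from compound 1 to compound 3 (0.09 log units; within the scatter).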

Compound 3, half-maximal inhibitory concentration: 46300 nM
The estimate for compound 3 lay 1.1-fold (0.03 log units) above the measured number, and the stated range covers the measured number.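

Unlike the earlier comparison, which gave only a floor, the change from 4-methoxyphenyl to 2-hydroxyphenyl on this nitrogen has a full number at both ends: a 1.1-fold higher number from compound 1 to compound 3 (0.05 log units; within the scatter) in this assay. At this position, the two groups therefore cannot be told apart in this read-out. The two hydroxyphenyl compounds also remain unordered, at an at least 1.0-fold lower number from compound 2 to compound 3 (0.03 log units; that floor lies within the scatter), because that step rests on a limit: the limit of > 50000 nM in this assay, at which 1 of the 3 values shown sits.

As far as these compounds go, whether an aminophenyl group, a carboxyphenyl group or a longer chain on this nitrogen would give a number clearly lower than those seen here remains open. From the compounds shown here alone, whether a change elsewhere on the shared core would shift the number in this assay also remains open.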